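This account rests on a few compounds, and the source may have more. Where it says the series, first, only, none or still open, it means among the compounds named here.

Measured so far in a functional assay on HCT-116 cells (Homo sapiens) for antiproliferative activity, read by CCK-8 assay, with a stated time of 72 h, tested at 8 uM; a higher number here means a stronger effect of the compound at the concentration tested, a lower number a weaker effect:
compound 1 `Cc1ccc(Nc2nc(Cl)nc3c2ncn3Cc2ccc(C(=O)Nc3ccccc3N)cc2)cc1` gives 81.5%;
compound 2 `Nc1ccccc1NC(=O)c1ccc(Cn2cnc3c(Nc4ccccc4)nc(Cl)nc32)cc1` gives 83.5%;
compound 3 `Nc1ccccc1NC(=O)/C=C/c1ccc(Cn2cnc3c(Nc4cccc(OC(F)(F)F)c4)nc(Cl)nc32)cc1` gives 5.23%.

Compound 3 stands lowest of the three numbers, beyond the scatter from both compound 1 and compound 2. Within the data shown here, the only measured single-place step, a number 2 percentage points higher from compound 1 to compound 2 (within the scatter), concerns hydrogen in place of methyl on an aromatic carbon and does not touch the present change. Compound 4 `Nc1ccccc1NC(=O)c1ccc(Cn2cnc3c(Nc4cccc(OC(F)(F)F)c4)nc(Cl)nc32)cc1` differs from compound 3 by (2-aminophenyl)carbamoyl in place of 2-((2-aminophenyl)carbamoyl)ethenyl on an aromatic carbon. Among the measured compounds shown here, no measured pair isolates this change; compound 3 differs from compound 1 and compound 2 in two places at once, so its low number cannot be assigned to either. A large rise is nonetheless expected, a number 64.8 percentage points higher from compound 3 to compound 4 (beyond the scatter), because compound 1 gives 81.5% and compound 2 gives 83.5% with the entering group in place. Compound 4 is estimated at 70%, within 35% to 92%.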

Compound 4, a percentage reported as inhibition, at one concentration (the size of the read-out at that concentration, not a potency): 46.6%
Compound 4: the middle estimate sits 23.4 percentage points above what was measured; the range from low to high includes it.
By their numbers in this assay, from the lowest: compound 3; then compound 4; then compounds 1 and 2 (each within the scatter of the next).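

In this assay, (2-aminophenyl)carbamoyl in place of 2-((2-aminophenyl)carbamoyl)ethenyl gives a number 41.4 percentage points higher from compound 3 to compound 4 (beyond the scatter) with the 3-(trifluoromethoxy)phenyl group held fixed. The group on the nitrogen also matters: trifluoromethoxy in place of hydrogen gives a number 36.9 percentage points lower from compound 2 to compound 4 (beyond the scatter) and 3-(trifluoromethoxy)phenyl in place of 4-methylphenyl gives a number 34.9 percentage points lower from compound 1 to compound 4 (beyond the scatter) with (2-aminophenyl)carbamoyl held fixed. No measured property bears on either change.

Open: whether the ethenyl-containing group lowers the number equally with phenyl or 4-methylphenyl on the nitrogen, and whether a methoxy or a fluorine in place of trifluoromethoxy follows the same step.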